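Methylphenyl series: the step to compound 3

The source may report more compounds than this note shows. Statements on the series, on what has been measured and on what is new or still open speak of the compounds shown alone.

Measured so far in a functional assay on Jurkat cells (Homo sapiens) for inhibition, read by CCK-8 assay, with a stated time of 48 h; on this read-out higher numbers stand for weaker inhibition of growth and lower numbers for stronger inhibition of growth:
compound 1 `Cc1ccccc1Nc1nc(Nc2ccc(N3CCN(C)CC3)cn2)ncc1Cl` gives 8080 nM
compound 2 `Cc1cccc(Nc2nc(Nc3ccc(N4CCN(C)CC4)cn3)ncc2Cl)c1` gives 15300 nM

For the measured compounds named here, compound 2, at 15300 nM, cannot be ordered against compound 1, the only other measured compound, as a 1.9-fold higher number from compound 1 to compound 2 (0.28 log units; within the scatter) is the only step available. Compound 3 `Cc1cc(C)c(Nc2nc(Nc3ccc(N4CCN(C)CC4)cn3)ncc2Cl)c(C)c1` is next, with 2,4,6-trimethylphenyl in place of 3-methylphenyl on a nitrogen on an aromatic ring. In words, this is 2,4,6-trimethylphenyl in place of 3-methylphenyl on a nitrogen on an aromatic ring. Going by the values given here, the one measured change in this group, 3-methylphenyl in place of 2-methylphenyl, is a 1.9-fold higher number from compound 1 to compound 2 (0.28 log units; within the scatter) and so offers little guidance. Among the compounds with values here, no measured compound carries more than one methyl group on this ring, so the added methyl groups are untested. No step beyond the scatter is expected in this assay, and no direction is favoured. The expected 1.4-fold lower number from compound 2 to compound 3 (0.14 log units; within the scatter) is only a working figure. Compound 3 is estimated at 11000 nM, with an expected range from 3500 nM to 35000 nM as a deliberately wide margin.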

Compound 3, concentration for 50% growth inhibition: 7600 nM
Compound 3: the middle estimate sits 1.4-fold (0.16 log units) above what was measured; the range from low to high includes it.
By their numbers in this assay, from the lowest: compounds 3, 1 and 2 (each within the scatter of the next).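

In this assay, the step to 2,4,6-trimethylphenyl on a nitrogen on an aromatic ring is a 2.0-fold lower number from compound 2 to compound 3 (0.30 log units; within the scatter) and, measured against the other single-methyl compound, a 1.1-fold lower number from compound 1 to compound 3 (0.03 log units; within the scatter). More than one methyl group on this ring is therefore compatible with values in the same range as those of compound 1 and compound 2, and neither step puts the three compounds in an order. Nothing available bears on why these values stay within the scatter of one another.

Still open, going by these compounds, is whether any group on this nitrogen can give a step beyond the scatter, for example cyclohexyl in place of the methylphenyl ring, or a phenyl ring carrying an amine or a carboxylic acid. Also open, on these data alone, is how the values respond to changes in the shared core, which is identical in all three compounds.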